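Thiosemicarbazones of a Monoterpene Isothiocyanate on Resistant Cells

A few compounds are considered here, and "the series" means these few. Any claim that something is new, unique, unknown or untested is made for them only; others in the source may bear on it.

Compound 1, `CC1=CC[C@H](C(C)(C)N=C=S)CC1`, gives in a functional assay on NCI/ADR-RES cells (Homo sapiens) for inhibition, read by sulforhodamine B assay, with a stated time of 48 h (a higher number here means a weaker inhibitor of growth, a lower number a stronger inhibitor of growth), a limit of > 100000 nM.
Compound 2, `CC1=CC[C@H](C(C)(C)NC(=S)N/N=C/c2ccc(O)cc2)CC1`, gives in this assay 82100 nM.
Compound 3, `CC1=CC[C@H](C(C)(C)NC(=S)N/N=C/c2cccc([N+](=O)[O-])c2)CC1`, gives in this assay a limit of > 100000 nM.

For the measured compounds named here, compound 2 therefore holds the only value that is a number in this assay; the two other results are the limit of > 100000 nM in this assay, at which 2 of the 3 values shown sit, so nothing can be said about any order among the three. Going by the values given here, no pair of measured compounds differs in one place, and no measured step is available to set a scale.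

Compound 4, `CC1=CC[C@H](C(C)(C)NC(=S)N/N=C/c2ccc[nH]2)CC1`, is not yet measured. It differs from compound 2 by 1H-pyrrol-2-yl in place of 4-hydroxyphenyl on a carbon with a double bond to nitrogen. Among the compounds with values here, with no measured step, the size of this change can only be guessed; the expectation for compound 4 is a step from compound 2 of a 1.2-fold higher number from compound 2 to compound 4 (0.06 log units; within the scatter), toward weaker inhibition of growth, and a real chance that only a limit is reported. The estimate for compound 4 in this assay is 95000 nM, with a range from 30000 nM to 300000 nM.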

Compound 4, concentration for 50% growth inhibition: 78000 nM
Estimate against measurement, compound 4: 1.2-fold (0.09 log units) above; measured number inside the range.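

This first measured step in the series shows that, on a carbon with a double bond to nitrogen, 1H-pyrrol-2-yl in place of 4-hydroxyphenyl gives a 1.1-fold lower number from compound 2 to compound 4 (0.02 log units; within the scatter) in this assay. At this place, then, a five-membered aromatic ring with 1 hetero atom and a six-membered aromatic ring of carbon only are not told apart by this read-out, although the entering group has fewer heavy atoms and no hydrogen-bond acceptor. Compound 1 and compound 3 remain limits rather than numbers, and the steps that involve them cannot be read: the limit of > 100000 nM in this assay, at which 2 of the 4 values shown sit.

From the compounds shown here alone, whether any group on this carbon can move growth inhibition beyond the scatter stays open, for instance a pyridine ring or a phenyl ring carrying an amine or a carboxylic acid. The compounds shown also leave open how much changes in the shared core would matter, since all of them keep it unchanged.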